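Swapping the amine on the thiocarbonyl carbon once more

The source may report more compounds than this note shows. Statements on the series, on what has been measured and on what is new or still open speak of the compounds shown alone.

Compound 1 `CC1CCN(C(=S)SCc2ccc(C(=O)Nc3ccccc3N)cc2)CC1` gives 81.9%. Compound 2 `CN(Cc1ccncc1)C(=S)SCc1ccc(C(=O)Nc2ccccc2N)cc1` gives 83.2%. Compound 3 `Nc1ccccc1NC(=O)c1ccc(CSC(=S)N2CCc3cc(Cl)ccc32)cc1` gives 82.2%.

All three were tested in a functional assay on MGC-803 cells (Homo sapiens) for antiproliferative activity, read by CCK-8 assay, with a stated time of 72 h, tested at 8 uM; on this read-out higher numbers stand for a stronger effect at the one concentration tested and lower numbers for a weaker effect. Compound 3 stands second highest of the three, with compound 1 its nearest neighbour and compound 2 its furthest, both within the scatter of it. Compound 4 `Nc1ccccc1NC(=O)c1ccc(CSC(=S)N2CCCC2)cc1` differs from compound 3 in one place: pyrrolidin-1-yl in place of 5-chloro-2,3-dihydro-1H-indol-1-yl on a thiocarbonyl carbon. Every measured step here changes the group on that same thiocarbonyl carbon, and each was small: a number 1.3 percentage points higher from compound 1 to compound 2 (within the scatter), a number 0.3 percentage points higher from compound 1 to compound 3 (within the scatter), a number 1 percentage points lower from compound 2 to compound 3 (within the scatter). On that basis no step beyond the scatter is expected for compound 4 in this assay, a change of a number 2.2 percentage points lower from compound 3 to compound 4 (within the scatter). Compound 4 is estimated at 80%, within 68% to 90%.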

Compound 4, a percentage reported as inhibition, at one concentration (the size of the read-out at that concentration, not a potency): 83.4%
Estimate against measurement, compound 4: 3.4 percentage points below; the range from low to high includes it.
By their numbers in this assay, from the lowest: compounds 1, 3, 2 and 4 (each within the scatter of the next).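

Going down from 5-chloro-2,3-dihydro-1H-indol-1-yl to pyrrolidin-1-yl on the thiocarbonyl carbon gives no step beyond the scatter in this assay: a number 1.2 percentage points higher from compound 3 to compound 4 (within the scatter), a number 0.2 percentage points higher from compound 2 to compound 4 (within the scatter) and a number 1.5 percentage points higher from compound 1 to compound 4 (within the scatter). Among these four compounds, this position therefore accepts the loss of the six-membered aromatic ring and the chlorine with no visible change in the read-out. Nothing available explains this result.

The compounds shown leave open whether a carboxylic acid or a primary amine on the pyrrolidine ring would shift the number. They also leave open whether the four compounds differ in potency, since one concentration cannot show that.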